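Moving the hydroxyl on one side arm of compound 3

The source may hold more compounds than are shown below. What is called first, only, known or untested is meant among the compounds shown, and "the series" means these compounds.

Compound 3 `Oc1ccc(-c2cc(-c3ccccc3OC(F)(F)F)cc(-c3ccccc3O)n2)cc1` gives the highest of three numbers in a functional assay on HCT-15 cells (Homo sapiens) for inhibition (a higher number here means a weaker inhibitor, a lower number a stronger inhibitor), namely 9820 nM; its neighbours, compound 2 `Oc1ccc(-c2cc(-c3ccccc3C(F)(F)F)cc(-c3cccc(O)c3)n2)cc1` with 5740 nM and compound 1 `Oc1ccc(-c2cc(-c3ccccc3F)cc(-c3cccc(O)c3)n2)cc1` with 5630 nM, both lie within the scatter of it, so no order among the three can be claimed. Compound 4 `Oc1ccc(-c2cc(-c3ccccc3OC(F)(F)F)cc(-c3cccc(O)c3)n2)cc1` differs from compound 3 by 3-hydroxyphenyl in place of 2-hydroxyphenyl on an aromatic carbon. Within the data shown here, no measured step matches this change: the only step available, a 1.0-fold higher number from compound 1 to compound 2 (0.01 log units; within the scatter), concerns a different group. Still, compounds 1 and 2 both carry the 3-hydroxyphenyl that enters, and their numbers sit within the scatter of compound 3, so in this assay no shift beyond the scatter is expected. The estimate for compound 4 is 7000 nM, between 3000 nM and 18000 nM, which means an expected 1.4-fold lower number from compound 3 to compound 4 (0.15 log units; within the scatter).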

Compound 4, half-maximal inhibitory concentration: 2310 nM
Compound 4: the middle estimate sits 3.0-fold (0.48 log units) above what was measured, outside the stated range (below it).
By their numbers in this assay, from the lowest: compound 4; then compounds 1, 2 and 3 (each within the scatter of the next).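

In this assay the place of the hydroxyl on this side arm matters: 3-hydroxyphenyl in place of 2-hydroxyphenyl gives a 4.3-fold lower number from compound 3 to compound 4 (0.63 log units; beyond the scatter) and so goes beyond the scatter. With 3-hydroxyphenyl held fixed, trifluoromethoxy also stands apart from two groups whose numbers lie within the scatter of each other, giving a 2.5-fold lower number from compound 2 to compound 4 (0.40 log units; beyond the scatter) against trifluoromethyl and a 2.4-fold lower number from compound 1 to compound 4 (0.39 log units; beyond the scatter) against fluoro. Nothing available explains these steps. Still open, as far as these compounds go, is whether an amine or a methoxy group in place of this hydroxyl would keep the gain.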